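A few compounds are considered here, and "the series" means these few. Any claim that something is new, unique, unknown or untested is made for them only; others in the source may bear on it.

In an assay on COS-7 cells for inhibition of patatin-like phospholipase domain-containing protein 2 (Mus musculus) (on this read-out lower numbers stand for stronger inhibition and higher numbers for weaker inhibition), compound 1 `CCOC(=O)c1cccc(-c2ccc3[nH]ccc3c2)c1` gives 60000 nM, and compound 2 `CCOC(=O)c1cccc(-c2ccc(CN3CCN(C)CC3)o2)c1` gives 120000 nM. Compound 3 `CCOc1ccc(-c2ccccc2)cc1` stands apart from these two: it sits at the limit of > 200000 nM in this assay, at which 1 of the 3 values shown sits, so its reading of > 200000 nM is a limit of the assay and not a number. Compound 4 `CCOc1ccc(-c2cccc(C(=O)OCCOC)c2)cc1` is compound 3 with (2-methoxyethoxy)carbonyl in place of hydrogen on an aromatic carbon. Among the compounds with values here, no measured pair shows this step, so the expectation rests on compound 1 and compound 2, which both carry an ester and give numbers rather than a limit. The step is therefore expected to run toward stronger inhibition, an at least 2.0-fold lower number from compound 3 to compound 4 (0.30 log units; that floor lies within the scatter), beyond the usual scatter. Compound 4 is estimated at 100000 nM, within a range from 40000 nM to 250000 nM.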

Compound 4, half-maximal inhibitory concentration: 70000 nM
Estimate against measurement, compound 4: 1.4-fold (0.15 log units) above; the measured number falls inside the stated range.
By their numbers in this assay, from the lowest: compounds 1, 4 and 2 (each within the scatter of the next). At a limit, above all of these: compound 3.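

In this assay, putting (2-methoxyethoxy)carbonyl in place of hydrogen on an aromatic carbon gives an at least 2.8-fold lower number from compound 3 to compound 4 (0.45 log units; beyond the scatter). Within the data shown here, compounds 1 and 2 also carry an ester, but neither has a partner without one, so this is the first direct view of what adding such a group does. The size of the step has only a floor, since compound 3 reads as a limit: the limit of > 200000 nM in this assay, at which 1 of the 4 values shown sits.

Which part of the group matters remains open. A carboxylic acid or an amide at the same place would test whether the ester itself is needed.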